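Amide variation on the carbonyl carbon: compound 3 to compound 4

A few compounds are considered here, and "the series" means these few. Any claim that something is new, unique, unknown or untested is made for them only; others in the source may bear on it.

In an in vitro ADME assay on microsomes from liver (Rattus norvegicus) for metabolic stability (a lower number here means that the compound disappears faster, a higher number that the compound lasts longer), compound 1 `CC(=O)n1cc(C(=O)O)c(Nc2ccc(I)cc2F)c1C` gives 0.35 h, compound 2 `CC(=O)c1cc(C(=O)O)c(Nc2ccc(I)cc2F)n1C` gives 0.117 h, and compound 3 `CC(=O)c1cc(C(=O)NOC(CO)CO)c(Nc2ccc(I)cc2F)n1C` gives 0.267 h. Compound 3 stands second highest of the three numbers: its value and that of compound 1 lie within the scatter of each other, while compound 2 sits lower, beyond the scatter. For the measured compounds named here, the one single-point step so far, a 2.3-fold higher number from compound 2 to compound 3 (0.36 log units; beyond the scatter), came with (2-hydroxy-1-(hydroxymethyl)ethoxy)amino in place of hydroxy on a carbonyl carbon.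

Compound 4 `CC(=O)c1cc(C(=O)N2CC[C@@H](O)C2)c(Nc2ccc(I)cc2F)n1C` differs from compound 3 by 3-hydroxypyrrolidin-1-yl in place of (2-hydroxy-1-(hydroxymethyl)ethoxy)amino on a carbonyl carbon. Going by the values given here, no measured step compares two such groups on the carbonyl carbon; the step from compound 2 to compound 3 bears only loosely on it, being a change of a different kind at the same place. Compound 4 is therefore expected to show a 1.1-fold higher number from compound 3 to compound 4 (0.05 log units; within the scatter), nothing beyond the scatter. Compound 4 is estimated at 0.3 h, with a range from 0.15 h to 0.6 h.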

Compound 4, half-life: 0.15 h
Compound 4: the middle estimate sits 2.0-fold (0.30 log units) above what was measured; the measured number falls inside the stated range.
By their numbers in this assay, from the lowest: compounds 2, 4, 3 and 1 (each within the scatter of the next, the first and the last beyond it).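

At this carbonyl carbon, this assay shows a 1.8-fold lower number from compound 3 to compound 4 (0.25 log units; within the scatter) with 3-hydroxypyrrolidin-1-yl in place of (2-hydroxy-1-(hydroxymethyl)ethoxy)amino, so these two groups are not separated here. The same ring in place of hydroxy gives a 1.3-fold higher number from compound 2 to compound 4 (0.11 log units; within the scatter), whereas (2-hydroxy-1-(hydroxymethyl)ethoxy)amino in place of hydroxy stays the only replacement read beyond the scatter (a 2.3-fold higher number from compound 2 to compound 3 (0.36 log units; beyond the scatter)). No supporting data bear on the reason for these readings.

Still open, from the compounds shown here alone, is how a longer chain carrying an amine would read on this carbonyl carbon. Going by these compounds, the other configuration of the 3-hydroxypyrrolidin-1-yl stereocentre also remains open.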